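Ring Amine in Place of Cyclohexylamine at the Chain Carbon

The source may report more compounds than this note shows. Statements on the series, on what has been measured and on what is new or still open speak of the compounds shown alone.

Compound 2 `FC(F)(F)c1ccc(Nc2nc(CNC3CCCCC3)nc3cc(-c4ncccc4C(F)(F)F)ccc23)cc1` holds the lower of the two numbers measured in a functional assay for antagonist activity at transient receptor potential cation channel subfamily V member 1 (Homo sapiens) (on this read-out lower numbers stand for stronger inhibition and higher numbers for weaker inhibition), where compound 2 gives 6 nM. Within the data shown here, compound 1 `CNCc1nc(Nc2ccc(C(F)(F)F)cc2)c2ccc(-c3ncccc3C(F)(F)F)cc2n1` gives 26 nM in this assay, and the single measured step, a 4.3-fold lower number from compound 1 to compound 2 (0.64 log units; beyond the scatter), came with cyclohexyl in place of methyl on an amine nitrogen. Compound 3 `FC(F)(F)c1ccc(Nc2nc(CN3CCCC3)nc3cc(-c4ncccc4C(F)(F)F)ccc23)cc1` differs from compound 2 by pyrrolidin-1-yl in place of cyclohexylamino on a saturated chain carbon bound to an aromatic carbon. Among the measured compounds shown here, no measured step covers the loss of a hydrogen-bond donor or the move to a smaller ring, so that step offers only loose guidance. The step from compound 2 to compound 3 is expected to be small, about a 2.5-fold higher number from compound 2 to compound 3 (0.40 log units; beyond the scatter). Compound 3 is estimated at 15 nM in this assay, between 5 nM and 45 nM.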

Compound 3, half-maximal inhibitory concentration: 25 nM
For compound 3 the middle estimate is 1.7-fold (0.22 log units) below the measured one; the range from low to high includes it.
By their numbers in this assay, from the lowest: compound 2; then compounds 3 and 1 (each within the scatter of the next).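

Placing pyrrolidin-1-yl on this chain carbon in place of cyclohexylamino gives a 4.2-fold higher number from compound 2 to compound 3 (0.62 log units; beyond the scatter) in this assay, so the cyclohexylamino group of compound 2 is not readily replaced by this ring amine. Pyrrolidin-1-yl and methylamino stand level, with a 1.0-fold lower number from compound 1 to compound 3 (0.02 log units; within the scatter), leaving compound 2 alone apart from the other two. Nothing available here explains these differences.

This change alters ring size and removes the hydrogen-bond donor together, and the compounds shown do not separate the two. Cyclopentylamino and piperidin-1-yl would each change only one of them.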